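The source may report more compounds than this note shows. Statements on the series, on what has been measured and on what is new or still open speak of the compounds shown alone.

Measured so far:
compound 1 `CCCCc1nc(C)c(CC(=O)N2CCCC2)c(=O)n1Cc1ccc(-c2ccccc2-c2nnn[nH]2)cc1` gives 0.056 mg/kg
compound 2 `CCCCc1nc(C)c(CC(=O)N2CCN(C)CC2)c(=O)n1Cc1ccc(-c2ccccc2-c2nnn[nH]2)cc1` gives "not determined" (no result reported)
compound 3 `CCCCc1nc(C)c(CC(=O)N2CCSCC2)c(=O)n1Cc1ccc(-c2ccccc2-c2nnn[nH]2)cc1` gives 0.038 mg/kg

In an in vivo functional assay on the whole organism for inhibition, with Rattus norvegicus as the target (on this read-out higher numbers stand for an effect only at larger amounts of compound and lower numbers for an effect already at smaller amounts), compound 3 gives 0.038 mg/kg and stands level with compound 1 within the scatter, while compound 2 offers no number for comparison. Compound 4 `CCCCc1nc(C)c(CCC(=O)N2CCOCC2)c(=O)n1Cc1ccc(-c2ccccc2-c2nnn[nH]2)cc1` carries 2-((morpholin-4-yl)carbonyl)ethyl where compound 3 carries ((thiomorpholin-4-yl)carbonyl)methyl. The counted change is ((morpholin-4-yl)carbonyl)methyl in place of (thiomorpholin-4-yl)carbonyl on a saturated chain carbon bound to an aromatic carbon and the rest of the structure stays the same. Within the data shown here, only one measured step bears on this: a 1.5-fold lower number from compound 1 to compound 3 (0.17 log units; within the scatter) stays within the scatter and concerns only the ring on the carbonyl carbon. Among the measured compounds shown here, no measured pair shows what the longer chain does, so that part of the change rests on no data and the range must stay wide. In this assay the expected step is a 1.6-fold higher number from compound 3 to compound 4 (0.20 log units; within the scatter) and it is estimated to stay small, with a slight lean toward a higher number. Compound 4 is estimated at 0.06 mg/kg with an expected range from 0.015 mg/kg to 0.25 mg/kg as the working figure.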

Compound 4, dose for half-maximal effect: 0.143 mg/kg
Compound 4: the middle estimate sits 2.4-fold (0.38 log units) below what was measured; the measured number falls inside the stated range.
By their numbers in this assay, from the lowest: compounds 3 and 1 (each within the scatter of the next); then compound 4.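

In this assay, the position on a saturated chain carbon bound to an aromatic carbon now gives a step beyond the scatter: a 3.8-fold higher number from compound 3 to compound 4 (0.58 log units; beyond the scatter), and likewise a 2.6-fold higher number from compound 1 to compound 4 (0.41 log units; beyond the scatter). Compound 1 and compound 3 stood within the scatter of each other, so the series at first showed little response here, whereas a change that alters both the chain and the ring on the carbonyl carbon does register. No measurement is at hand that speaks to the cause of these steps.

The shares of the chain and the ring remain inseparable, and ((morpholin-4-yl)carbonyl)methyl or 2-((thiomorpholin-4-yl)carbonyl)ethyl at this place would divide them. Also open, from the compounds shown here alone, is how a still longer chain, or a carboxylic acid in place of the amide, would read in this assay.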